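This account rests on a few compounds, and the source may have more. Where it says the series, first, only, none or still open, it means among the compounds named here.

Among the measured compounds shown here, in a functional assay on A549 cells (Homo sapiens) for antiproliferative activity, read by MTT assay, with a stated time of 72 h (a higher number here means a weaker inhibitor, a lower number a stronger inhibitor), compound 3 `CCOc1ccc(-c2c(C(=O)c3cc(OC)c(OC)c(OC)c3)sc3ccccc23)cc1` gives 3100 nM, the lower of the two true numbers so far. Compound 1 `COc1cc(C(=O)c2sc3ccccc3c2-c2ccc(C)cc2)cc(OC)c1OC` gives 7800 nM. Compound 2 `COc1ccc(-c2c(C(=O)c3cc(OC)c(OC)c(OC)c3)sc3ccccc23)cc1C` gives > 10000 nM, which is a limit of the assay and not a number.

Compound 4 `COc1cc(C(=O)c2sc3ccccc3c2Nc2ccccc2)cc(OC)c1OC`, still unmeasured, has anilino in place of 4-ethoxyphenyl on an aromatic carbon. The measured compounds differ only in the group at this same place, so two steps bear on the change: a 2.5-fold lower number from compound 1 to compound 3 (0.40 log units; beyond the scatter) and an at least 3.2-fold lower number from compound 2 to compound 3 (0.50 log units; beyond the scatter). Neither involves anilino, so they offer only a rough guide. Both favour 4-ethoxyphenyl, so a modest step to a higher number is expected in this assay. The expected change is a 1.8-fold higher number from compound 3 to compound 4 (0.25 log units; within the scatter). For compound 4 the estimated value is 5500 nM, within an expected range of 1500 nM to 10000 nM.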

Compound 4, half-maximal inhibitory concentration: 3000 nM
Beside the measured number, compound 4's estimate is 1.8-fold (0.26 log units) above it; low and high end bracket the measured number.
By their numbers in this assay, from the lowest: compounds 4 and 3 (each within the scatter of the next); then compound 1. At a limit, above all of these: compound 2.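

At this place on the shared core, anilino, which brings a hydrogen-bond donor that 4-ethoxyphenyl lacks, holds up in this assay, with a 1.0-fold lower number from compound 3 to compound 4 (0.01 log units; within the scatter). Anilino also compares well with the methyl-bearing ring, with a 2.6-fold lower number from compound 1 to compound 4 (0.41 log units; beyond the scatter). Compound 2 stands at a limit and not a number, which leaves only a floor for the step, an at least 3.3-fold lower number from compound 2 to compound 4 (0.52 log units; beyond the scatter): the limit of > 10000 nM in this assay, at which 1 of the 4 values shown sits.

Going by these compounds, whether the linking nitrogen or the attached ring matters more remains open. A 4-ethoxyanilino group, or a small amine such as methylamino, at this place would help separate the two.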